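The source may hold more compounds than are shown below. What is called first, only, known or untested is meant among the compounds shown, and "the series" means these compounds.

Compound 1 `CCOC(=O)c1c(C)oc2ncnc(Nc3cccc(C)c3)c12`: > 1000000 nM
Compound 2 `CCOC(=O)c1c(C)oc2ncnc(Nc3ccc(OCc4cccc(F)c4)c(Cl)c3)c12`: 500 nM

Both compounds were tested in a functional assay on A549 cells (Homo sapiens) for cytotoxicity, read by MTT assay, with a stated time of 72 h; a lower number here means a stronger inhibitor, a higher number a weaker inhibitor. For compound 1, the entry > 1000000 nM is a limit of the assay and not a number. Compound 2, by contrast, gives a true measured value of 500 nM.

Compound 3 `CCOC(=O)c1c(C)oc2ncnc(Nc3ccccc3)c12` has not yet been measured. It differs from compound 1 at a single place: hydrogen in place of methyl on an aromatic carbon. This is hydrogen in place of methyl on an aromatic carbon, so 3-methylphenyl becomes phenyl.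

The expectation rests on compound 1, whose only reading is the limit > 1000000 nM. The expected step of a number no higher from compound 1 to compound 3 (the limit leaves the size open) stays within the usual scatter, with neither direction favoured. Compound 3 may well return only a limit too. The estimate for compound 3 is 1000000 nM, with an expected range from 200000 nM to 2000000 nM.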

Compound 3, half-maximal inhibitory concentration: > 1000000 nM
Compound 3 ended at the assay's limit; the forecaster's own chance of this, stated with the estimate: 65%; the middle value lies on the limit itself.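

Compound 3 gives > 1000000 nM, which is a limit of the assay and not a number. Compound 1 also stands only at a limit, so no step can be read between compound 1 and compound 3. As far as these compounds go, whether 3-methylphenyl and phenyl differ at all in this assay stays open.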